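Fluoro and bromo substitution in a diaryl ether oxime series

The source may hold more compounds than are shown below. What is called first, only, known or untested is meant among the compounds shown, and "the series" means these compounds.

Compound 1 `O=[N+]([O-])c1cc(C(F)(F)F)cc([N+](=O)[O-])c1Oc1ccccc1/C=N\OCc1ccccc1` is the parent of the set; in a functional assay on A549 cells (Homo sapiens) for antiproliferative activity, read by MTT assay, with a stated time of 48 h (a lower number here means a stronger inhibitor, a higher number a weaker inhibitor), compound 1 gives 1470 nM. Compound 2 `O=[N+]([O-])c1cc(C(F)(F)F)cc([N+](=O)[O-])c1Oc1ccccc1/C=N\OCc1ccccc1F` carries the change (fluoro in place of hydrogen on an aromatic carbon), and compound 2 gives 860 nM, the step being a 1.7-fold lower number from compound 1 to compound 2 (0.23 log units; within the scatter). Compound 3 `O=[N+]([O-])c1cc(C(F)(F)F)cc([N+](=O)[O-])c1Oc1ccc(Br)cc1/C=N\OCc1ccccc1` has a different core: the two cores differ in bromo in place of hydrogen on an aromatic carbon. In this assay compound 3 gives 2240 nM, and the step is a 1.5-fold higher number from compound 1 to compound 3 (0.18 log units; within the scatter). Among the measured compounds shown here, no single step links compound 2 and compound 3; their two numbers simply stand as given, compound 2 at the lower and compound 3 at the higher end of the measured set. Compound 4 `O=[N+]([O-])c1cc(C(F)(F)F)cc([N+](=O)[O-])c1Oc1ccc(Br)cc1/C=N\OCc1ccccc1F` has not been measured; it differs from compound 3 in fluoro in place of hydrogen on an aromatic carbon. This is the same change that carries compound 1 to compound 2, and the words describing the place around it are identical for both pairs. The expected step of a 1.7-fold lower number from compound 3 to compound 4 (0.24 log units; within the scatter) is estimated from the measured step of a 1.7-fold lower number from compound 1 to compound 2 (0.23 log units; within the scatter), which lay within the scatter, applied to compound 3 at 2240 nM. Compound 4 is therefore expected to give 1300 nM in this assay, with an estimated range from 600 nM to 3000 nM.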

Compound 4, half-maximal inhibitory concentration: 1280 nM
Beside the measured number, compound 4's estimate is 1.0-fold (0.01 log units) above it; measured number inside the range.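

In this assay, fluoro in place of hydrogen on the benzyl group gives a 1.8-fold lower number from compound 3 to compound 4 (0.24 log units; within the scatter), and this agrees with the same change on the core without bromo: the same change on two cores in this assay, a 1.7-fold lower number (0.23 log units; within the scatter) from compound 1 to compound 2 and a 1.8-fold lower number (0.24 log units; within the scatter) from compound 3 to compound 4, 1.0-fold (0.01 log units) apart, within the scatter of two such steps Bromo in place of hydrogen on the core gives a 1.5-fold higher number from compound 2 to compound 4 (0.17 log units; within the scatter), and this likewise agrees with the earlier step: the same change on two cores in this assay, a 1.5-fold higher number (0.18 log units; within the scatter) from compound 1 to compound 3 and a 1.5-fold higher number (0.17 log units; within the scatter) from compound 2 to compound 4, 1.0-fold (0.01 log units) apart, within the scatter of two such steps Within these four compounds, each change therefore carries from one core to the other with no difference in step size beyond the scatter, but all four steps themselves lie within the scatter, so this does not show that either change alters the number on its own, nor that the agreement extends to other cores.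

As far as these compounds go, whether chloro or methoxy in place of the fluoro, or an amine or a carboxylic acid in place of the bromo, would carry over in the same way remains open. Also open, from the compounds shown here alone, is whether any change gives a step beyond the scatter that holds on both cores.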